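One Methyl on a Hydroxy Group: What to Expect

The compounds below may be only part of what the source reports. "The series", "measured", "known", "first", "only" and "open" are said of these compounds alone.

Compound 1 `CC(=O)Oc1ccc(CC[C@@H](O)CCCCc2ccccc2)cc1OC(C)=O` gives 330 nM
Compound 2 `O=C(/C=C/C=C/c1cccc(O)c1)/C=C/c1cccc(O)c1` gives 580 nM

Both values come from a functional assay on RAW264.7 cells (Mus musculus) for inhibition, read by Griess assay, with stated times of 2 h and 24 h (on this read-out lower numbers stand for stronger inhibition and higher numbers for weaker inhibition), and lie within the usual scatter of repeated measurements of each other. Compound 2 therefore stands level with compound 1, and these numbers cannot rank the two.

Compound 3 `COc1cccc(/C=C/C=C/C(=O)/C=C/c2cccc(O)c2)c1` keeps the structure of compound 2 with one change: methyl in place of hydrogen on an oxygen on an aromatic ring, or hydroxy to methoxy methyl in place of hydrogen on an oxygen on an aromatic ring in a single place. Going by the values given here, no pair of measured compounds shows this kind of swap, so the data give no direct size for it. The natural starting point is compound 2 at 580 nM in this assay and the cautious expectation is a small shift towards weaker inhibition, one that may not clear the scatter. The expected change is a 1.4-fold higher number from compound 2 to compound 3 (0.14 log units; within the scatter) as a rough estimate. For compound 3 the estimated value is 800 nM with an expected range from 280 nM to 2300 nM as a working figure.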

Compound 3, half-maximal inhibitory concentration: 410 nM
Estimate against measurement, compound 3: 2.0-fold (0.29 log units) above, and the stated range covers the measured number.
By their numbers in this assay, from the lowest: compounds 1, 3 and 2 (each within the scatter of the next).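

This pair gives the first direct size for this change. In this assay, putting methyl in place of hydrogen on an oxygen on an aromatic ring, which turns hydroxy into methoxy, gives a 1.4-fold lower number from compound 2 to compound 3 (0.15 log units; within the scatter), so compound 2 and compound 3 stand level and the numbers cannot rank them. At this one place, then, the hydrogen of the hydroxy group can be replaced by methyl with no readable loss or gain of inhibition, although a single pair cannot show that the same would hold elsewhere, and no measurement at hand offers an explanation for the result.

The compounds shown leave open what a larger or different group would do at this oxygen or in place of the hydroxy group, such as an ethoxy group, an amine or a carboxylic acid. They also leave open whether the same swap on the hydroxy group that remains in compound 3 would again stay within the scatter, or whether a compound with both groups as methoxy would read differently.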